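This account rests on a few compounds, and the source may have more. Where it says the series, first, only, none or still open, it means among the compounds named here.

Working notes on the series.

Compound 1 is `COc1cc(-c2ncnn2-c2ccc(Cl)cc2Cl)cc(OC)c1OC`. In a functional assay on Jurkat cells (Homo sapiens) for antiproliferative activity, read by MTT assay, with a stated time of 72 h (a lower number here means a stronger inhibitor, a higher number a weaker inhibitor), compound 1 gives only a limit, > 10000 nM. Compound 2 is `COc1cc(-n2ncnc2-c2cccc(F)c2)cc(OC)c1OC`. In this assay compound 2 likewise gives only a limit, > 10000 nM. Compound 3 is `COc1ccc(-c2ncnn2-c2cc(OC)c(OC)c(OC)c2)cc1` and in this assay compound 3 gives 50 nM. For the measured compounds named here, the one measured step, an at least 200-fold lower number from compound 2 to compound 3 (2.30 log units; beyond the scatter), is the only one with a number at both ends worth the name; two of the three values shown sit at the limit of > 10000 nM in this assay, at which 2 of the 3 values shown sit, so compound 1 stands there with compound 2, with no number of its own to rank against compound 3.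

Compound 4 is `COc1cc(-c2ncnn2-c2ccc(Cl)cc2)cc(OC)c1OC`. It differs from compound 1 by hydrogen in place of chloro on an aromatic carbon; cut one bond further out, this reads 2,4-dichlorophenyl to 4-chlorophenyl. Going by the values given here, no measured step removes a chloro group, so the step from compound 2 to compound 3 bears on it only loosely: it shows that the aryl group on the shared core can move the value by a large amount, and that the 4-methoxyphenyl of compound 3 carries a number while the 3-fluorophenyl of compound 2 gives a limit. A step into the measurable range is therefore expected for compound 4, of uncertain size, with the chance that the limit is met again. The estimate for compound 4 in this assay is 1500 nM, between 150 nM and 10000 nM, meaning an expected step of an at least 6.6-fold lower number from compound 1 to compound 4 (0.82 log units; beyond the scatter).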

Compound 4, half-maximal inhibitory concentration: > 10000 nM
Compound 4 ended at the assay's limit; the forecaster's own chance of this, stated with the estimate: 35%; at least 6.6-fold (0.82 log units) between middle value and limit.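

Compound 1 and compound 4 both give only a limit in this assay, so the step between them cannot be read: the limit of > 10000 nM in this assay, at which 3 of the 4 values shown sit. The compounds shown leave open whether hydrogen in place of chloro on an aromatic carbon moves the value at all, as neither compound 1 nor compound 4 has a number of its own.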